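Allyloxy in Place of Benzyloxy on a Sultone Scaffold

This account rests on a few compounds, and the source may have more. Where it says the series, first, only, none or still open, it means among the compounds named here.

Compound 1 `CCC1(Cc2ccccc2)OS(=O)(=O)C=C1OCc1ccccc1` is measured in an ADME assay on HEL cells (Homo sapiens) for cytotoxicity, with a stated time of 3 days; a higher number here means that more compound is tolerated, a lower number that less compound is tolerated. In this assay compound 1 gives >= 50000 nM, which is a limit of the assay and not a number, so that compound 1 sits at the limit of >= 50000 nM in this assay, at which 1 of the 3 values shown sits. Compound 2 `CC1(C(c2ccccc2)c2ccccc2)OS(=O)(=O)C=C1OCc1ccccc1` gives >= 400000 nM in this assay, again a limit, the one described by the limit of >= 400000 nM in this assay, at which 1 of the 3 values shown sits. Compound 3 `CCC1(Cc2ccccc2)OS(=O)(=O)C=C1OCc1ccc(Br)cc1` gives 80000 nM in this assay, a measured number. For the measured compounds named here, the only one-place step among the measured compounds, a step that the limit leaves unreadable from compound 1 to compound 3, cannot be read because compound 1 only reaches a limit, so its size stays unknown.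

Compound 4 `C=CCOC1=CS(=O)(=O)OC1(CC)Cc1ccccc1` differs from compound 1 by vinyl in place of phenyl on a saturated chain carbon bound to an oxygen on an unsaturated carbon. No measured step touches the benzyloxy side of the core, so nothing shown predicts a direction for this change. The measured number of compound 3 and the limit of compound 1 both lie in the same high region, and compound 4 is expected to stay there too, with a step that the limit leaves unreadable from compound 1 to compound 4 and an estimated value of 90000 nM, ranging from 30000 nM to 400000 nM.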

Compound 4, minimum cytotoxic concentration: 80000 nM
Beside the measured number, compound 4's estimate is 1.1-fold (0.05 log units) above it, within the range that was stated.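

For the compounds shown here, with vinyl in place of 4-bromophenyl on a saturated chain carbon bound to an oxygen on an unsaturated carbon, this assay shows no change at the digits printed from compound 3 to compound 4 (within the scatter), the first step at this position that can be read. Between these two compounds, then, the read-out does not depend on keeping the aromatic ring at this place, and the allyloxy group of compound 4 gives the same printed value as the 4-bromobenzyloxy group of compound 3. The step that starts at compound 1 cannot be read because compound 1 gives a limit and not a number: the limit of >= 50000 nM in this assay, at which 1 of the 4 values shown sits.

The compounds shown leave open whether an amine or a carboxylic acid at the end of this chain would move the read-out in this assay. They also leave open whether a longer chain in place of the allyl would keep it where it stands.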